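Side-chain changes at one chain carbon and cytotoxicity

The source may report more compounds than this note shows. Statements on the series, on what has been measured and on what is new or still open speak of the compounds shown alone.

Measured compounds:
compound 1, `COc1cc(NC(C)CCCN2C(=O)CN(C(=O)[C@H](N)CCSC)C2(C)C)c2ncccc2c1`, 7900 nM
compound 2, `COc1cc(NC(C)CCCN2C(=O)CN(C(=O)[C@@H](C)N)C2(C)C)c2ncccc2c1`, 7800 nM

In an ADME assay on A549 cells (Homo sapiens) for cytotoxicity, with a stated time of 72 h (a lower number here means a stronger inhibitor, a higher number a weaker inhibitor), compound 1 gives 7900 nM, and compound 2 gives 7800 nM. Compound 2 and compound 1 lie within the scatter of each other, as the step of a 1.0-fold lower number from compound 1 to compound 2 (0.01 log units; within the scatter) shows. Compound 3, `COc1cc(NC(C)CCCN2C(=O)CN(C(=O)[C@H](N)CC(C)C)C2(C)C)c2ncccc2c1`, differs from compound 2 by isopropyl in place of hydrogen on a saturated chain carbon, two bonds along the chain from an amine nitrogen and a carbonyl carbon. Among the compounds with values here, the only measured step at this chain carbon is a 1.0-fold lower number from compound 1 to compound 2 (0.01 log units; within the scatter), which was within the scatter, so the step of a 1.0-fold lower number from compound 2 to compound 3 (0.02 log units; within the scatter) is expected to stay within the scatter as well. Compound 3 is therefore estimated at 7500 nM, with a range from 3000 nM to 20000 nM.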

Compound 3, half-maximal inhibitory concentration: 21200 nM
Beside the measured number, compound 3's estimate is 2.8-fold (0.45 log units) below it, outside the stated range (above it).
By their numbers in this assay, from the lowest: compounds 2 and 1 (each within the scatter of the next); then compound 3.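

In this assay this chain carbon now shows a change beyond the scatter: isopropyl in place of hydrogen gives a 2.7-fold higher number from compound 2 to compound 3 (0.43 log units; beyond the scatter) and isopropyl in place of (methylsulfanyl)methyl gives a 2.7-fold higher number from compound 1 to compound 3 (0.43 log units; beyond the scatter) at the same carbon. The number at this carbon therefore does depend on the group it carries, although hydrogen and (methylsulfanyl)methyl had read alike. No measurement shown here accounts for the rise. The compounds shown leave open whether a straight butyl chain would read like isopropyl or like (methylsulfanyl)methyl. They also leave open how a phenyl ring, an amine or a carboxylic acid would read on this carbon.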